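The compounds below may be only part of what the source reports. "The series", "measured", "known", "first", "only" and "open" are said of these compounds alone.

Measured in an ADME assay on microsomes from liver (Mus musculus, strain CD-1) for pharmacokinetics, read by LC-MS, with a stated time of 60 min, tested at 1 uM; a lower number here means slower removal, a higher number faster removal of the compound:
- compound 1 `O=C(NCc1ccc(S(=O)(=O)c2ccccc2)cc1)N1Cc2ccncc2C1`: 75 mL/min/kg
- compound 2 `CC(C)n1cc(S(=O)(=O)c2ccc(CNC(=O)N3Cc4ccncc4C3)cc2)cn1`: 71 mL/min/kg

Compound 2, at 71 mL/min/kg, cannot be told apart from compound 1, at 75 mL/min/kg. The two differ only in the group on the sulfonyl sulfur, and the measured step is a 1.1-fold lower number from compound 1 to compound 2 (0.02 log units; within the scatter).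

Compound 3 `O=C(NCc1ccc(S(=O)(=O)C2CCN(C3COC3)CC2)cc1)N1Cc2ccncc2C1` changes that same place again, with 1-(oxetan-3-yl)piperidin-4-yl in place of 1-isopropyl-1H-pyrazol-4-yl on a sulfonyl sulfur. For the measured compounds named here, only one measured step bears on this change, the exchange of phenyl for 1-isopropyl-1H-pyrazol-4-yl that gave compound 2, a 1.1-fold lower number from compound 1 to compound 2 (0.02 log units; within the scatter). Going by the values given here, that step links two aromatic groups, whereas the entering group is non-aromatic, and no measured compound shows what such a group does here. The evidence therefore gives only weak guidance, and the expectation is a modest move towards a lower number that stays within the scatter. The expected change is a 1.4-fold lower number from compound 2 to compound 3 (0.15 log units; within the scatter). For compound 3 the estimated clearance is 50 mL/min/kg, with an expected range of 22 mL/min/kg to 85 mL/min/kg.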

Compound 3, clearance: 56 mL/min/kg
Estimate against measurement, compound 3: 1.1-fold (0.05 log units) below, within the range that was stated.
By their numbers in this assay, from the lowest: compounds 3, 2 and 1 (each within the scatter of the next).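

In this assay, the step to a non-aromatic group on the sulfonyl sulfur is a 1.3-fold lower number from compound 2 to compound 3 (0.10 log units; within the scatter), and measured from the phenyl group it is a 1.3-fold lower number from compound 1 to compound 3 (0.13 log units; within the scatter). The earlier pair had only compared two aromatic groups, whereas these steps show that 1-(oxetan-3-yl)piperidin-4-yl, with its four-membered and six-membered non-aromatic rings, can stand at this place without a step beyond the scatter. Nothing available explains why the three compounds lie so close together in this read-out.

The compounds shown leave open whether any group on this sulfonyl sulfur can give a step beyond the scatter, since a small alkyl group such as methyl, a longer open chain or a carboxylic acid does not appear among them. They also leave open what each part of the entering group contributes, as a piperidin-4-yl group carrying a free amine hydrogen in place of the oxetan-3-yl group would be needed to compare the two rings separately.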